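Piperidine substituent swap in the shared amide series

A few compounds are considered here, and "the series" means these few. Any claim that something is new, unique, unknown or untested is made for them only; others in the source may bear on it.

Three compounds of the shared core have been run in a functional assay on CHO-K1 cells for antagonist activity at melanin-concentrating hormone receptor 1 (Homo sapiens), read by inositol phosphate accumulation, with stated times of 10 min and 45 min; a lower number here means a stronger inhibitor, a higher number a weaker inhibitor. Compound 1 `Cc1ccc(/C=C/C(=O)Nc2ccc3nc(N4CCC(O)(C5CC5)CC4)nc(C)c3c2)cc1` gives 107 nM, compound 3 `COCCC1(O)CCN(c2nc(C)c3cc(NC(=O)/C=C/c4ccc(Cl)cc4)ccc3n2)CC1` gives 220 nM, and compound 2 `Cc1nc(N2CCC(N3C(=O)CCC3=O)CC2)nc2ccc(NC(=O)/C=C/c3ccc(OC(F)(F)F)cc3)cc12` gives 35 nM. Compound 2 holds the lowest number of the three, and its gaps to compound 1 and to compound 3 both lie beyond the scatter. The next compound, compound 4 `Cc1nc(N2CCC(N3CCOC3=O)CC2)nc2ccc(NC(=O)/C=C/c3ccc(OC(F)(F)F)cc3)cc12`, differs from compound 2 in one place: 2-oxo-1,3-oxazolidin-3-yl in place of 2,5-dioxopyrrolidin-1-yl on a saturated ring carbon. Among the compounds with values here, no step between two measured compounds matches this change, so no measured precedent exists. The change keeps the ring count and the acceptor count, so a step within the scatter is expected, in no preferred direction; the estimated step of a 1.3-fold higher number from compound 2 to compound 4 (0.11 log units; within the scatter) reflects that. Compound 4 is expected to give about 45 nM, within 15 nM to 130 nM.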

Compound 4, half-maximal inhibitory concentration: 31 nM
Compound 4: middle estimate off by 1.5-fold (0.16 log units), on the high side; the range from low to high includes it.
By their numbers in this assay, from the lowest: compounds 4 and 2 (each within the scatter of the next); then compound 1; then compound 3.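

In this assay, 2-oxo-1,3-oxazolidin-3-yl in place of 2,5-dioxopyrrolidin-1-yl on a saturated ring carbon gives a 1.1-fold lower number from compound 2 to compound 4 (0.05 log units; within the scatter). Within the data shown here, this is the first one-place step, and it shows that, with the rest of compound 2 held constant, these two five-membered rings cannot be told apart at this position. No measured property bears on this result.

Still open, as far as these compounds go, is whether a non-ring group on this carbon, such as a carboxylic acid or a dimethylamino group, would read alike. The compounds shown also leave open whether the same ring exchange gives a similar step with other groups on the amide side.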